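Methylsulfanyl for Methoxy on the Benzamide of Compound 3

This account rests on a few compounds, and the source may have more. Where it says the series, first, only, none or still open, it means among the compounds named here.

Compound 1 `COc1cc(C(F)(F)F)cc(C(F)(F)F)c1C(=O)NC1(c2ccccc2)CCCN(C2CCCC2)C1`: in an assay on cells for inhibition of sodium- and chloride-dependent glycine transporter 1 (Homo sapiens) (a higher number here means that more compound is needed for the effect, a lower number that less compound is needed), compound 1 gives 270 nM.
Compound 2 `COc1cc(C(F)(F)F)cc(C(F)(F)F)c1C(=O)NC1(c2ccccc2)CCCN(C(=O)c2ccccc2)C1`: in this assay compound 2 gives only > 10000 nM, which is a limit of the assay and not a number.
Compound 3 `COc1cc(C(F)(F)F)ccc1C(=O)NC1(c2ccccc2)CCCN(C)C1`: in this assay compound 3 gives 4800 nM.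

Among the two numbers measured, compound 3 stands highest; its nearest neighbour is compound 1, whose number is lower by a margin beyond the usual scatter. Among the compounds with values here, the only step measured between neighbouring compounds is an at least 37-fold higher number from compound 1 to compound 2 (1.56 log units; beyond the scatter), a change on the ring nitrogen, with compound 2 ending at the assay limit (the limit of > 10000 nM in this assay, at which 1 of the 3 values shown sits). That step touches a different part of the shared core and does not bear on the present change.

Compound 4 `CSc1cc(C(F)(F)F)ccc1C(=O)NC1(c2ccccc2)CCCN(C)C1` differs from compound 3 by methylsulfanyl in place of methoxy on an aromatic carbon. Within the data shown here, with no measured step informing this exchange, the step from compound 3 to compound 4 is expected to be about a 1.2-fold lower number from compound 3 to compound 4 (0.08 log units; within the scatter), that is, nothing beyond the scatter. Compound 4 is therefore estimated at 4000 nM in this assay, within a range from 1500 nM to 12000 nM.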

Compound 4, half-maximal effective concentration: 67 nM
For compound 4 the middle estimate is 60-fold (1.78 log units) above the measured one; the whole stated range lies above it.
By their numbers in this assay, from the lowest: compound 4; then compound 1; then compound 3. At a limit, above all of these: compound 2.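

In this assay methylsulfanyl in place of methoxy gives a 72-fold lower number from compound 3 to compound 4 (1.86 log units; beyond the scatter) and so shows that this position, on an aromatic carbon ortho to a large group, strongly affects the number. Within the data shown here, the earlier step, an at least 37-fold higher number from compound 1 to compound 2 (1.56 log units; beyond the scatter), lay on the ring nitrogen, so the new step is the first measured sign that the benzamide side of the shared core also matters. The two exchanged groups have the same counts of heavy atoms, hydrogen-bond donors and acceptors and the same lack of net charge, and nothing measured here accounts for the size of this step.

Going by these compounds, whether other groups at this position, such as ethylsulfanyl, chlorine or an amine, lower the number as far remains open. On these data alone, it is also open whether methylsulfanyl gives a similar step on the core of compound 1, with cyclopentyl on the ring nitrogen.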